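The source may report more compounds than this note shows. Statements on the series, on what has been measured and on what is new or still open speak of the compounds shown alone.

In a functional assay on PC-3 cells (Homo sapiens) for cytotoxicity, read by MTT assay, with a stated time of 48 h (a lower number here means a stronger inhibitor, a higher number a weaker inhibitor), three compounds sharing one core have been tested so far. Compound 1 `COc1ccc(/C=C/C(=O)/C=C/c2cc3ccccc3nc2Cl)c(OC)c1` gives > 10000 nM, which is a limit of the assay and not a number. Compound 3 `COc1cc(OC)c(/C=C/C(=O)/C=C/c2cc3ccccc3nc2Cl)c(OC)c1` gives > 10000 nM, which is also a limit. For the measured compounds named here, compound 2 `COc1cc(OC)c(OC)cc1/C=C/C(=O)/C=C/c1cc2ccccc2nc1Cl` gives 3120 nM, the only actual number among the three.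

Compound 4 `COc1cc(OC)c(OC)cc1/C=C/C(=O)/C=C/c1cc2ccccc2nc1Oc1ccccc1` differs from compound 2 in one place: phenoxy in place of chloro on an aromatic carbon. This is phenoxy in place of chloro on an aromatic carbon, next to the ring nitrogen.

Going by the values given here, no measured step touches the chloro, so the two available steps offer only loose guidance. Methoxy in place of hydrogen gave an at least 3.2-fold lower number from compound 1 to compound 2 (0.50 log units; beyond the scatter), while the same kind of swap at another place gave a step that the two limits leave unreadable from compound 1 to compound 3. The first shows that one change elsewhere on the core can matter, but it does not give a direction for this swap. The best single guess is therefore no step beyond the scatter, with a wide margin towards weaker values.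

The expected change is a 1.3-fold higher number from compound 2 to compound 4 (0.11 log units; within the scatter). For compound 4 the estimate is 4000 nM, with an expected range from 1200 nM to 10000 nM.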

Compound 4, half-maximal inhibitory concentration: 7290 nM
The estimate for compound 4 lay 1.8-fold (0.26 log units) below the measured number; measured number inside the range.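

Until now, every step shown swapped hydrogen for methoxy elsewhere on the shared core, so nothing showed how the position next to the ring nitrogen behaves. In this assay, replacing chloro with phenoxy there gives a 2.3-fold higher number from compound 2 to compound 4 (0.37 log units; beyond the scatter). In this one pair, a group of 7 heavy atoms carrying its own aromatic ring, in place of a single chlorine, costs only a modest step, and compound 4 still gives an actual number rather than a limit.

From the compounds shown here alone, with one swap at this position, it remains open whether the step comes from losing chloro or from gaining phenoxy, and how an amine or a longer chain would behave there. Comparisons across the series also stay thin: the limit of > 10000 nM in this assay, at which 2 of the 4 values shown sit.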